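Substituent swap on the aromatic ring: bromo to methoxy

A few compounds are considered here, and "the series" means these few. Any claim that something is new, unique, unknown or untested is made for them only; others in the source may bear on it.

Measured so far, in a toxicity assay on THP-1 cells (Homo sapiens) for inhibition; a lower number here means that less compound is tolerated, a higher number that more compound is tolerated:
Compound 1 `COc1ccc(-c2cnc(NC(=O)c3ccccc3C#N)n2C)cc1`: compound 1 reaches only the assay limit > 100000 nM.
Compound 2 `COc1ccc(-c2cnc(NC(=O)c3ccccc3Br)n2C)cc1`: compound 2 likewise reaches only the assay limit > 100000 nM.

Compound 1 and compound 2 differ by bromo in place of cyano on an aromatic carbon; the step that the two limits leave unreadable from compound 1 to compound 2 cannot be read, as both values are limits. Going by the values given here, compound 2 therefore stands at the limit of > 100000 nM in this assay, at which 2 of the 2 values shown sit, with no number of its own; the one other value shown is the same limit.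

Compound 3 `COc1ccc(-c2cnc(NC(=O)c3ccccc3OC)n2C)cc1` carries the change (methoxy in place of bromo on an aromatic carbon). Among the compounds with values here, no measured step bears on this change: the only step available, from compound 1 to compound 2, is unreadable, so it gives no guide to the direction or size of the step into compound 3. Both measured compounds sit at the limit, and the expected outcome for compound 3 is a repeat of that limit rather than a readable number. Compound 3 is expected to be tolerated at a high concentration, estimated at 100000 nM (range 40000 nM to 300000 nM). The expected step of a number no higher from compound 2 to compound 3 (the limit leaves the size open) is none beyond the scatter.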

Compound 3, half-maximal cytotoxic concentration: > 100000 nM
Compound 3: no number, only a limit; the forecaster's own chance of this, stated with the estimate: 85%; the middle value lies on the limit itself.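

In this assay compound 3 gives > 100000 nM, a limit of the assay and not a number. Going by these compounds alone, no step among compound 1, compound 2 and compound 3 can be read, as all three share one limit: the limit of > 100000 nM in this assay, at which 3 of the 3 values shown sit. The compounds shown leave open where each one's tolerated concentration lies and whether cyano, bromo and methoxy differ at all.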